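A few compounds are considered here, and "the series" means these few. Any claim that something is new, unique, unknown or untested is made for them only; others in the source may bear on it.

Working notes on the series. In a functional assay on MCF7 cells (Homo sapiens) for inhibition, in the presence of a further agent that is not named here (on this read-out lower numbers stand for stronger inhibition and higher numbers for weaker inhibition), compound 1 (`Nc1ccc(-c2cc(=O)c3c(N)c(F)cc(F)c3o2)cc1F`) gives 25 nM as its value, compound 2 (`Cc1ccc(N)c2c(=O)cc(-c3ccc(N)c(F)c3)oc12`) gives 180 nM as its value, and compound 3 (`Nc1ccc(-c2cc(=O)c3c(N)ccc(F)c3o2)cc1`) gives 170 nM as its value. Compound 3 therefore stands level with compound 2, within the scatter, and its number is clearly higher than that of compound 1. Among the measured compounds shown here, no two measured compounds differ in one place only, so no measured step isolates a single group.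

Next in line is compound 4 (`Nc1ccc(-c2cc(=O)c3c(N)cccc3o2)cc1`), which departs from compound 3 by hydrogen in place of fluoro on an aromatic carbon in one place, with hydrogen in place of fluoro on an aromatic carbon. The series holds no direct measure of this change in this assay, so any expectation is loose. Compound 1, at 25 nM and differing from compound 3 in more than one place, does not settle the direction. The expected change is a 2.4-fold lower number from compound 3 to compound 4 (0.39 log units; beyond the scatter) as estimated, a modest move toward a lower number, held with low confidence and with a range that also allows a higher one. For compound 4 the estimated value is 70 nM with an expected range from 10 nM to 300 nM as its upper end.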

Compound 4, half-maximal inhibitory concentration: 210 nM
Beside the measured number, compound 4's estimate is 3.0-fold (0.48 log units) below it; the range from low to high includes it.
By their numbers in this assay, from the lowest: compound 1; then compounds 3, 2 and 4 (each within the scatter of the next).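

Among the compounds shown here, this is the first single-place step, and it isolates the fluoro para to an amino group on the fused ring system. In this assay, a 1.2-fold higher number from compound 3 to compound 4 (0.09 log units; within the scatter), so with hydrogen in place of fluoro on this aromatic carbon the two compounds stand level, and this read-out does not separate the two groups here. That finding holds only for the compound 3 and compound 4 pair, in which no other part of the structure differs, and it cannot be extended to fluoro on other aromatic carbons of the series. No supporting measurement bears on this result, and the step itself offers no account of it.

From the compounds shown here alone, whether chloro, methoxy or a carboxylic acid on this same aromatic carbon would stand level with fluoro and hydrogen remains open. Compound 1, at 25 nM, differs from compound 4 in more than one place, so its value cannot yet be assigned to any single group.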